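Compound 4: benzothiazol-2-yl in place of 4-methylphenyl

A few compounds are considered here, and "the series" means these few. Any claim that something is new, unique, unknown or untested is made for them only; others in the source may bear on it.

Series notes. Compound 1 `COc1c(OCCCCN2CCN(C)CC2)cc(O)c2c(=O)cc(-c3ccc(C)cc3)oc12` gives 5430 nM in a functional assay on B16 cells (Mus musculus) for cytotoxicity, read by MTT assay, with a stated time of 72 h; on this read-out lower numbers stand for stronger inhibition and higher numbers for weaker inhibition. For the measured compounds named here, compound 2 `COc1c(OCCCCN2CCN(C)CC2)cc(O)c2c(=O)cc(-c3ccc(Cl)cc3)oc12` gives 2090 nM in this assay, and the only single-point step measured so far is a 2.6-fold lower number from compound 1 to compound 2 (0.41 log units; beyond the scatter). Compound 3 `Cc1ccc(COc2cc(O)c3c(=O)cc(-c4ccccc4)oc3c2OCCCCN2CCN(C)CC2)cc1` gives 3290 nM in this assay; this number lies within the scatter of both compound 2 and compound 1, so nothing further can be read from the three numbers beyond the step just named.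

Compound 4 `CN1CCN(CCCCOc2c(OCc3nc4ccccc4s3)cc(O)c3c(=O)cc(-c4ccccc4)oc23)CC1` differs from compound 3 by 1,3-benzothiazol-2-yl in place of 4-methylphenyl on a saturated chain carbon bound to an oxygen on an aromatic ring. Going by the values given here, the one measured step concerns a chloro for methyl exchange on an aromatic carbon elsewhere in the molecule, not the group on the saturated chain carbon bound to the aromatic oxygen; no measured pair bears on the change from compound 3 to compound 4. Among the compounds with values here, with no measured step of this kind, the expectation for this assay is a step of no size beyond the scatter, in no set direction. Compound 4 is therefore estimated at 3200 nM, with a range of 1000 nM to 10000 nM. The expected step of a 1.0-fold lower number from compound 3 to compound 4 (0.01 log units; within the scatter) thus stays within the scatter.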

Compound 4, half-maximal inhibitory concentration: 2780 nM
Compound 4: the middle estimate sits 1.2-fold (0.06 log units) above what was measured, within the range that was stated.
By their numbers in this assay, from the lowest: compounds 2, 4, 3 and 1 (each within the scatter of the next, the first and the last beyond it).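

In this assay, for the compounds shown here, 1,3-benzothiazol-2-yl in place of 4-methylphenyl gives a 1.2-fold lower number from compound 3 to compound 4 (0.07 log units; within the scatter), the first measured step on a saturated chain carbon bound to an oxygen on an aromatic ring. The change brings in a five-membered aromatic ring with 2 hetero atoms and 2 hydrogen-bond acceptors, where the group that leaves has 0, and the read-out shows no difference beyond the scatter for this pair. No measurement at hand accounts for this result.

The compounds shown leave open whether an amine or a carboxylic acid in this place would move the number beyond the scatter. Also open, going by these compounds, is whether 4-chlorophenyl here would give a step like a 2.6-fold lower number from compound 1 to compound 2 (0.41 log units; beyond the scatter), which was seen at a different place in the molecule.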